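Bromo for methoxy in a weakly antiproliferative pair

This account rests on a few compounds, and the source may have more. Where it says the series, first, only, none or still open, it means among the compounds named here.

Measured compounds:
compound 1, `COc1ccccc1OCCNc1cnn(Cc2ccc(OC(F)F)c(OCC3CC3)c2)c(=O)c1Cl`: 67600 nM
compound 2, `COc1ccc(Cn2nc(NCCOc3ccccc3OC)ccc2=O)cc1OC`: > 100000 nM

In a functional assay on K562 cells (Homo sapiens) for antiproliferative activity, read by MTT assay, with a stated time of 48 h (a lower number here means a stronger inhibitor of growth, a higher number a weaker inhibitor of growth), compound 1 gives 67600 nM. For compound 2 the assay reports only a limit, > 100000 nM, so compound 2 stands at the limit of > 100000 nM in this assay, at which 1 of the 2 values shown sits, and no number is known for it. Compound 3, `COc1ccc(Cn2nc(NCCOc3ccccc3OC)ccc2=O)cc1Br`, carries bromo in place of methoxy on an aromatic carbon. Among the measured compounds shown here, no step between measured compounds is on record here, so the pair gives no direction to read. For compound 3 the expected step is an at least 1.1-fold lower number from compound 2 to compound 3 (0.04 log units; that floor lies within the scatter), nothing beyond the scatter, with a second limit likely. Compound 3 is estimated at 90000 nM, range 30000 nM to 300000 nM.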

Compound 3, concentration for 50% growth inhibition: > 100000 nM
Compound 3 was reported as a limit; the forecaster's own chance of this, stated with the estimate: 60%; at least 1.1-fold (0.04 log units) between middle value and limit.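

No step can be read between compound 2 and compound 3, as both are reported only as limits: the limit of > 100000 nM in this assay, at which 2 of the 3 values shown sit.

As far as these compounds go, whether the change from 3,4-dimethoxyphenyl to 3-bromo-4-methoxyphenyl alters growth inhibition at all, and in which direction, stays open.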